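This account rests on a few compounds, and the source may have more. Where it says the series, first, only, none or still open, it means among the compounds named here.

Measured compounds in the series:

compound 1 `CN1CCC[C@@H]1Cn1nc(CCc2ccccc2)c2ccccc2c1=O` — 200 nM
compound 2 `CN1CCC[C@@H]1Cn1nc(Cc2cccc(F)c2)c2ccccc2c1=O` — 50.1 nM

Both numbers come from an assay for binding affinity to Alpha-1A adrenergic receptor (Homo sapiens); on this read-out higher numbers stand for weaker inhibition and lower numbers for stronger inhibition. Compound 2 has the lowest number of the two; the one step shown, a 4.0-fold lower number from compound 1 to compound 2 (0.60 log units; beyond the scatter), separates it from compound 1.

Compound 3 `COc1cccc(Cc2nn(C[C@H]3CCCN3C)c(=O)c3ccccc23)c1` is not yet measured. It differs from compound 2 in one place: methoxy in place of fluoro on an aromatic carbon. The group sits on an aromatic carbon of a six-membered aromatic ring of carbon only, meta to a large group.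

Within the data shown here, no measured step bears on this swap. The step of a 4.0-fold lower number from compound 1 to compound 2 (0.60 log units; beyond the scatter) concerns a different change at a different place, so it gives no direct guide to the exchange of fluoro for methoxy. With nothing to draw on, the expected step from compound 2 to compound 3 is none beyond the scatter, written as a 1.2-fold higher number from compound 2 to compound 3 (0.08 log units; within the scatter). Among the measured compounds shown here, compound 3 is therefore estimated at 60 nM in this assay, with a range from 20 nM to 180 nM; the range is wide because no measured step covers this change.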

Compound 3, inhibition constant: 1580 nM
For compound 3 the middle estimate is 26-fold (1.42 log units) below the measured one; the whole stated range lies below it.
By their numbers in this assay, from the lowest: compound 2; then compound 1; then compound 3.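

Methoxy in place of fluoro at this position on the aromatic ring is far from a neutral exchange in this assay: it gives a 32-fold higher number from compound 2 to compound 3 (1.50 log units; beyond the scatter), a larger step than the only earlier one, a 4.0-fold lower number from compound 1 to compound 2 (0.60 log units; beyond the scatter). The change to 3-methoxyphenyl also gives a 7.9-fold higher number from compound 1 to compound 3 (0.90 log units; beyond the scatter), so methoxy does more than cancel the earlier gain and leaves compound 3 the weakest of the three. Nothing available accounts for the size of these steps.

As far as these compounds go, whether this steep loss is peculiar to methoxy or extends to other groups on the same aromatic carbon, such as chloro, hydroxy or the longer ethoxy, remains open, as does whether fluoro and methoxy would rank the same on the other carbons of that ring. The step to the 3-fluorobenzyl compound also alters the chain and the ring substituent together, so the share of fluoro alone in that earlier gain stays unresolved, and a plain unsubstituted phenyl on the same short chain would be the direct reference for both substituents.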